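This account rests on a few compounds, and the source may have more. Where it says the series, first, only, none or still open, it means among the compounds named here.

Among the measured compounds shown here, in an ADME assay on microsomes from liver (Homo sapiens) for metabolic stability, with a stated time of 30 min (on this read-out higher numbers stand for a more stable compound and lower numbers for a less stable compound), compound 2 `Cc1nc(N2CCC(N3CCNC3=O)CC2)nc2ccc(NC(=O)/C=C/c3ccc(OC(F)(F)F)cc3)cc12` gives 83%, the only number of this set. For the measured compounds named here, compound 1 `Cc1nc(NCCNC(=O)C2CC2)nc2ccc(NC(=O)/C=C/c3ccc(OC(F)(F)F)cc3)cc12` carries "not determined" (no result reported) in this assay, and compound 3 `Cc1nc(NCCCNS(C)(=O)=O)nc2ccc(NC(=O)/C=C/c3ccc(OC(F)(F)F)cc3)cc12` likewise carries "not determined" (no result reported), so compound 2 stands alone and no step between measured compounds can be drawn. Compound 4 `Cc1nc(N2CCC(N3CCN(C)C3=O)CC2)nc2ccc(NC(=O)/C=C/c3ccc(OC(F)(F)F)cc3)cc12` differs from compound 2 by a single change, (methyl in place of hydrogen on an amide-type nitrogen in a ring), described as methyl in place of hydrogen on an amide-type nitrogen in a ring. Going by the values given here, with no comparable step on record, compound 4 is expected to stay close to compound 2, with a step of a number 5 percentage points lower from compound 2 to compound 4 (within the scatter) that lies within the usual scatter of this assay. The estimate for compound 4 is therefore 78%, within 60% to 92%.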

Compound 4, percent of the compound remaining: 33%
Compound 4: the middle estimate sits 45 percentage points above what was measured, outside the stated range (below it).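

In this assay, methyl in place of hydrogen on an amide-type nitrogen in a ring gives a number 50 percentage points lower from compound 2 to compound 4 (beyond the scatter) and so shows that the read-out responds strongly to this position. Among the compounds shown here, one added carbon on the 2-oxoimidazolidin-1-yl group is enough, something that compound 2 alone, as the only number available earlier, could not show. Nothing given here accounts for this step. The compounds shown leave open how ethyl, acetyl or a longer chain on the same nitrogen would compare with hydrogen and methyl.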